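A few compounds are considered here, and "the series" means these few. Any claim that something is new, unique, unknown or untested is made for them only; others in the source may bear on it.

Measured so far:
compound 1 `O=C(O)CCc1cc(Cc2cccnc2)cc2c1CCC(NS(=O)(=O)c1ccc(Cl)cc1)C2` — 1100 nM
compound 2 `O=C(O)CCc1c2c(cc(Cc3cccnc3)c1-c1ccccc1)CC(NS(=O)(=O)c1ccc(Cl)cc1)CC2` — > 10000 nM (a limit of the assay)

Among the measured compounds shown here, in an assay on blood with Thromboxane-A synthase (Homo sapiens) as the target (a lower number here means a stronger inhibitor, a higher number a weaker inhibitor), compound 1 gives 1100 nM; it is the only plain number. For compound 2 the assay reports a limit only, > 10000 nM, which places compound 2 at the limit of > 10000 nM in this assay, at which 1 of the 2 values shown sits. For the measured compounds named here, the single measured step, an at least 9.0-fold higher number from compound 1 to compound 2 (0.95 log units; beyond the scatter), is therefore itself bounded from one side only; it concerns phenyl in place of hydrogen on an aromatic carbon and does not touch the acid chain.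

Compound 3 `O=C(O)CCC/C=C/c1cc(Cc2cccnc2)cc2c1CCC(NS(=O)(=O)c1ccc(Cl)cc1)C2` differs from compound 1 at the acid chain: 5-carboxypent-1-en-1-yl in place of 2-carboxyethyl on an aromatic carbon. The place is ortho to a fused ring and meta to the (pyridin-3-yl)methyl group. Going by the values given here, no measured step alters this chain, so the step from compound 1 to compound 2 offers no guidance on direction or size here. With nothing to anchor the expectation, the estimate stays near compound 1 with a wide spread. Compound 3 is expected at 800 nM, between 200 nM and 4000 nM. The expected step is then a 1.4-fold lower number from compound 1 to compound 3 (0.14 log units; within the scatter), not beyond the scatter.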

Compound 3, half-maximal inhibitory concentration: > 5000 nM
Compound 3 was reported as a limit; the forecaster's own chance of this, stated with the estimate: 10%; middle value at least 6.2-fold (0.79 log units) away from the limit.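

In this assay compound 3 is reported only as a limit of the assay, not as a number: the limit of > 5000 nM in this assay, at which 1 of the 3 values shown sits.

The step, an at least 4.5-fold higher number from compound 1 to compound 3 (0.65 log units; beyond the scatter), is bounded from one side only but lies beyond the scatter, so this position on the aromatic carbon ortho to a fused ring does not tolerate every acid chain: 5-carboxypent-1-en-1-yl in place of 2-carboxyethyl keeps the carboxylic acid yet gives a weaker inhibitor. The earlier step, an at least 9.0-fold higher number from compound 1 to compound 2 (0.95 log units; beyond the scatter), left the acid chain untouched and said nothing about it, whereas the chain itself is now seen to matter, and both steps out of compound 1 lead to a higher number.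

The change adds length and a double bond together, and the compounds shown do not separate the two, so what a saturated 5-carboxypentyl chain would give remains open. Also open, on these data alone, are the true size of the loss, which only a plain number could fix, and whether a shorter chain such as carboxymethyl at this place would go the same way.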